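Bromo for Methyl at the Ortho Position of Compound 2

A few compounds are considered here, and "the series" means these few. Any claim that something is new, unique, unknown or untested is made for them only; others in the source may bear on it.

Measured compounds:
Compound 1, `O=C1/C(=C/c2ccccc2[N+](=O)[O-])CCc2ccccc21`, 8120 nM
Compound 2, `Cc1ccccc1/C=C1\CCc2ccccc2C1=O`, 41400 nM

In a functional assay on Molt4/C8 cells (Homo sapiens) for inhibition (on this read-out lower numbers stand for stronger inhibition and higher numbers for weaker inhibition), compound 2 gives 41400 nM, the highest of the two numbers available. Its nearest neighbour is compound 1, and the step of a 5.1-fold higher number from compound 1 to compound 2 (0.71 log units; beyond the scatter) separates them, a difference that lies beyond the usual scatter and is described as modest.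

Compound 3, `O=C1/C(=C/c2ccccc2Br)CCc2ccccc21`, has not yet been measured in this assay. The change from compound 2 is bromo in place of methyl on an aromatic carbon, at a place on an aromatic carbon of a six-membered aromatic ring of carbon only, ortho to a large group.

Within the data shown here, only one measured step bears on this change: the step of a 5.1-fold higher number from compound 1 to compound 2 (0.71 log units; beyond the scatter), where nitro was exchanged for methyl at the same carbon. Bromo is neither of those groups, so the direction is not fixed by the data; the single step only shows that substitution at this position can shift the number by a modest amount.

Compound 3 is therefore expected to give 20000 nM in this assay, between 7000 nM and 55000 nM, which corresponds to an estimated step of a 2.1-fold lower number from compound 2 to compound 3 (0.32 log units; beyond the scatter).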

Compound 3, half-maximal inhibitory concentration: 36800 nM
Estimate against measurement, compound 3: 1.8-fold (0.26 log units) below, and the stated range covers the measured number.
By their numbers in this assay, from the lowest: compound 1; then compounds 3 and 2 (each within the scatter of the next).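

In this assay, putting bromo in place of methyl on this aromatic carbon gives no separable difference (a 1.1-fold lower number from compound 2 to compound 3 (0.05 log units; within the scatter)), so the two groups cannot be told apart at this place. Bromo in place of nitro, by contrast, gives a step beyond the scatter (a 4.5-fold higher number from compound 1 to compound 3 (0.66 log units; beyond the scatter)), so the gap first seen with methyl is not peculiar to methyl: among these three compounds, compound 1, with its nitro group, alone stands apart, with the lowest number. Nothing measured here accounts for this difference between nitro and the other two groups.

What the compounds leave open is whether nitro is unusual at this carbon or whether methyl and bromo are the ones that hold the number high, since three groups at a single place give no trend to read. An amine, a carboxylic acid or a methoxy group at the same carbon could settle whether other groups fall with compound 1 or with compound 2 and compound 3, and the bare ring without any group there would supply the missing reference point.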